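The source may hold more compounds than are shown below. What is called first, only, known or untested is meant among the compounds shown, and "the series" means these compounds.

Measured so far:
compound 1 `CC(C)(C)c1onc(-c2c(Cl)cccc2Cl)c1COc1ccc(/C=C/c2cccc(C(=O)O)c2)c(Cl)c1` — 1300 nM
compound 2 `CC(C)c1onc(-c2c(Cl)cccc2Cl)c1COc1ccc(C(=O)Nc2cccc(C(=O)O)c2)c(Cl)c1` — 3000 nM

In a functional assay on HEK293 cells for agonist activity at Bile acid receptor (Homo sapiens) (a higher number here means that more compound is needed for the effect, a lower number that less compound is needed), compound 2 gives 3000 nM, the higher of the two numbers; compound 1 gives 1300 nM, and the gap between them lies beyond the scatter. Compound 3 `CC(C)c1onc(-c2c(Cl)cccc2Cl)c1COc1ccc(C(=O)N(Cc2ccccc2)c2cccc(C(=O)O)c2)c(Cl)c1` differs from compound 2 by benzyl in place of hydrogen on an amide-type nitrogen. Among the measured compounds shown here, no measured pair shows this kind of change, so its effect is unknown here. A step of moderate size toward a higher number is expected, as estimated by a 2.7-fold higher number from compound 2 to compound 3 (0.43 log units; beyond the scatter). In this assay compound 3 is therefore expected to give about 8000 nM, within a range from 2000 nM to 30000 nM.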

Compound 3, half-maximal effective concentration: 2500 nM
Compound 3: the middle estimate sits 3.2-fold (0.51 log units) above what was measured, within the range that was stated.
By their numbers in this assay, from the lowest: compounds 1, 3 and 2 (each within the scatter of the next, the first and the last beyond it).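

In this assay, putting benzyl in place of hydrogen on the amide-type nitrogen gives a 1.2-fold lower number from compound 2 to compound 3 (0.08 log units; within the scatter), so the two compounds cannot be told apart. Among the compounds shown here, this is the first sign that, in this series, the amide hydrogen can be replaced by a much larger group, one carrying an aromatic ring, without a step beyond the scatter. Nothing available here explains this result. From the compounds shown here alone, whether methyl, a longer chain such as phenethyl, or a benzyl bearing an amine or a carboxylic acid would behave the same at this nitrogen remains open.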